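Ester aryl changes on a shared flavone core: cytotoxicity notes

The compounds below may be only part of what the source reports. "The series", "measured", "known", "first", "only" and "open" are said of these compounds alone.

Measured so far:
Compound 1 `COC(=O)c1ccc(C)cc1OC(=O)COc1cc(O)c2c(=O)cc(-c3ccccc3)oc2c1` gives 250000 nM in an ADME assay on cells (T-cell, Mus musculus, strain BALB/c) for cytotoxicity, read by MTT assay, with a stated time of 48 h; on this read-out higher numbers stand for lower toxicity in this test and lower numbers for higher toxicity in this test.
Compound 2 `COC(=O)c1cccc(C)c1OC(=O)COc1cc(O)c2c(=O)cc(-c3ccccc3)oc2c1` gives 299000 nM in this assay.
Compound 3 `COC(=O)c1cc(F)ccc1OC(=O)COc1cc(O)c2c(=O)cc(-c3ccccc3)oc2c1` gives 389000 nM in this assay.

The three compounds share one core and differ only in the aryl group on the oxygen next to a carbonyl group. Compound 3 carries the highest of the three numbers, yet the step to its nearest neighbour is a 1.3-fold higher number from compound 2 to compound 3 (0.11 log units; within the scatter) and the step to the furthest is a 1.6-fold higher number from compound 1 to compound 3 (0.19 log units; within the scatter); both fall within scatter, as does a 1.2-fold higher number from compound 1 to compound 2 (0.08 log units; within the scatter), so no ranking of compounds 1, 2 and 3 is supported.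

Compound 4 `COC(=O)c1ccccc1OC(=O)COc1cc(O)c2c(=O)cc(-c3ccccc3)oc2c1` differs from compound 3 by hydrogen in place of fluoro on an aromatic carbon. Going by the values given here, no measured step removes a single fluorine on its own; the steps that bear on it are the whole-aryl swaps above, each within scatter, and the exchange of an entire substituted aryl group for another moved this assay no further than that. A single fluoro-to-hydrogen change is therefore expected to give no step beyond scatter, that is a 1.2-fold lower number from compound 3 to compound 4 (0.08 log units; within the scatter).

For compound 4 the expected value in this assay is 320000 nM, with a range from 160000 nM to 640000 nM.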

Compound 4, half-maximal cytotoxic concentration: 265000 nM
For compound 4 the middle estimate is 1.2-fold (0.08 log units) above the measured one; low and high end bracket the measured number.
By their numbers in this assay, from the lowest: compounds 1, 4, 2 and 3 (each within the scatter of the next).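

The direct exchange of fluoro for hydrogen, on an aromatic carbon meta to a methoxycarbonyl group and para to a large group, gives a 1.5-fold lower number from compound 3 to compound 4 (0.17 log units; within the scatter) in this assay, so this single-atom change at this position can now be read on its own and does not leave the scatter. Hydrogen in place of methyl on an aromatic carbon reads the same way, with a 1.1-fold lower number from compound 2 to compound 4 (0.05 log units; within the scatter) and a 1.1-fold higher number from compound 1 to compound 4 (0.03 log units; within the scatter), which means that neither of the two methyl placements can be told apart from the plain aryl group in this test. No measurement is at hand that explains these small steps.

Going by these compounds, whether an amine or a carboxylic acid on this aromatic carbon, or a longer chain in place of the methyl of the methoxycarbonyl group, would give a step beyond the scatter remains open. All four compounds carry the shared core and the same link to the aryl group, so the compounds shown say nothing about how changes in those parts would read in this assay.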